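The source may report more compounds than this note shows. Statements on the series, on what has been measured and on what is new or still open speak of the compounds shown alone.

Measured so far in a functional assay on B16-F10 cells (Mus musculus) for antiproliferative activity, read by MTT assay, with a stated time of 48 h; a lower number here means a stronger inhibitor, a higher number a weaker inhibitor:
Compound 1 `COc1ccc(/C=C/c2cc(OC)cc(OC)c2/C=C/C(=O)c2ccc(Cl)c(Cl)c2)cc1`: 7.5 ug/mL
Compound 2 `COc1ccc(/C=C/c2cc(OC)cc(OC)c2/C=C/C(=O)c2ccccc2C)cc1`: 6.1 ug/mL

Only these two compounds have been measured in this assay, and compound 2, at 6.1 ug/mL, cannot be told apart from the other one, since the two numbers lie within the usual scatter of each other. The next compound to be measured is compound 3 `COc1ccc(/C=C/c2cc(OC)cc(OC)c2/C=C/C(=O)c2ccc(C)c(C)c2)cc1`. It keeps the shared core and changes one group, with 3,4-dimethylphenyl in place of 2-methylphenyl on a carbonyl carbon.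

Among the compounds with values here, one measured step bears on this change. It concerns the same place on the molecule, where 2-methylphenyl replaced 3,4-dichlorophenyl, and it amounts to a 1.2-fold lower number from compound 1 to compound 2 (0.09 log units; within the scatter). Within the data shown here, that single step is small, and no measurement yet shows how a 3,4-dimethylphenyl group behaves here. No move beyond the scatter is therefore expected, in either direction. The estimated size of the change is a 1.1-fold higher number from compound 2 to compound 3 (0.03 log units; within the scatter). For compound 3 the expected value is 6.5 ug/mL, with an estimated range from 3.5 ug/mL to 12 ug/mL.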

Compound 3, half-maximal inhibitory concentration: 1.4 ug/mL
The estimate for compound 3 lay 4.6-fold (0.67 log units) above the measured number, and the stated range ends above it.
By their numbers in this assay, from the lowest: compound 3; then compounds 2 and 1 (each within the scatter of the next).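

In this assay, the group on the carbonyl carbon now proves able to move the number beyond the scatter, which the earlier pair of compounds did not show: 3,4-dimethylphenyl in place of 2-methylphenyl gives the first such step (a 4.4-fold lower number from compound 2 to compound 3 (0.64 log units; beyond the scatter)). The same group in place of 3,4-dichlorophenyl gives a step of similar standing (a 5.4-fold lower number from compound 1 to compound 3 (0.73 log units; beyond the scatter)), so 3,4-dimethylphenyl and 3,4-dichlorophenyl are not interchangeable at this place, and compound 3 is the strongest inhibitor of the three shown. Nothing measured here accounts for this gain.

From the compounds shown here alone, what remains open is whether the gain needs both methyl groups or follows from where they stand, since 2-methylphenyl differs from 3,4-dimethylphenyl in both respects and a 3-methylphenyl or 4-methylphenyl group would be needed to separate the two. Going by these compounds, it is also open how far the trend reaches, for instance whether 3,4-diethylphenyl, 3,4-dimethoxyphenyl or a ring carrying an amine would hold the number of compound 3, and all of this rests on a single modest step in one cell line.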